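From Methoxy to Methyl on the Aromatic Ring

A few compounds are considered here, and "the series" means these few. Any claim that something is new, unique, unknown or untested is made for them only; others in the source may bear on it.

Within the data shown here, compound 2 `CCC(C(=O)N1CCN(c2cccc(OC)c2)CC1)N1C(=O)CCC1=O` gives 0% in a functional assay on the whole organism (strain Swiss) with Mus musculus as the target, in the maximal electroshock model, with a stated time of 2 h, at a dose of 300 mg/kg by the intraperitoneal route (on this read-out lower numbers stand for a weaker effect and higher numbers for a stronger effect at the one dose given), the lowest of the two numbers so far, while compound 1 `CCC(C(=O)N1CCN(c2ccc(Cl)cc2)CC1)N1C(=O)CCC1=O` gives 25%. Among the measured compounds shown here, the one measured step, a number 25 percentage points lower from compound 1 to compound 2 (beyond the scatter), exchanged the whole aromatic substituent and so says little about the change leading to compound 3 `CCC(C(=O)N1CCN(c2cccc(C)c2)CC1)N1C(=O)CCC1=O`, which is methyl in place of methoxy on an aromatic carbon. Nothing measured bears on methoxy against methyl, so no step beyond the scatter is expected in this assay, with room only upward from compound 2. Compound 3 is therefore estimated at 10%, in the range 0% to 30%. The expected step is a number 10 percentage points higher from compound 2 to compound 3 (within the scatter).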

Compound 3, a percentage reported as activity, at one dose (the size of the read-out at that dose, not a potency): 0%
Estimate against measurement, compound 3: 10 percentage points above; low and high end bracket the measured number.
By their numbers in this assay, from the lowest: compounds 2 and 3 (each within the scatter of the next); then compound 1.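

In this assay, methyl in place of methoxy gives no change at the digits printed from compound 2 to compound 3 (within the scatter), so at this position, meta to a large group, losing the oxygen of methoxy does not alter the reading. The other step, a number 25 percentage points lower from compound 1 to compound 3 (beyond the scatter), has 3-methylphenyl in place of 4-chlorophenyl and shows that the low reading is not tied to methoxy alone. No measured evidence offers a reason for this result.

Still open, on these data alone, is whether chlorine itself or its place on the ring separates compound 1 from compound 2 and compound 3, since both differ together. Also open, as far as these compounds go, is how an amine or a carboxylic acid in place of methyl at this position would read.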